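The compounds below may be only part of what the source reports. "The series", "measured", "known", "first", "only" and "open" are said of these compounds alone.

Compound 1, `CS/C(=N\C(=O)c1sccc1Cl)NC(=O)c1sccc1Cl`, gives only a limit in a functional assay on HepG2 cells (Homo sapiens) for cytotoxicity, read by MTT assay, with a stated time of 72 h; a higher number here means a weaker inhibitor of growth, a lower number a stronger inhibitor of growth: > 100000 nM. Compound 2, `CS/C(=N\C(=O)c1csc([N+](=O)[O-])c1)NC(=O)c1csc([N+](=O)[O-])c1`, likewise reaches only the limit of this assay: > 100000 nM. Compound 3, `O=C(/N=C(/NC(=O)c1csc([N+](=O)[O-])c1)[Se]Cc1ccccc1)c1csc([N+](=O)[O-])c1`, gives 62800 nM.

Going by the values given here, compound 3 thus holds the only actual number here, since the limit of > 100000 nM in this assay, at which 2 of the 3 values shown sit, covers the other two. Among the compounds with values here, the one measured step, an at least 1.5-fold lower number from compound 2 to compound 3 (0.20 log units; that floor lies within the scatter), brought a number out of that limit by replacing a small sulfur-bearing group with a benzyl-selenium group. Compound 4, `C[Se]/C(=N\C(=O)c1csc([N+](=O)[O-])c1)NC(=O)c1csc([N+](=O)[O-])c1`, differs from compound 3 by hydrogen in place of phenyl on a saturated chain carbon bound to a selenium atom, which undoes part of that same change and moves compound 4 back towards compound 2. A rise in the number, possibly back to the limit, is therefore expected for compound 4, with a 1.5-fold higher number from compound 3 to compound 4 (0.18 log units; within the scatter) as the estimated step. The estimate for compound 4 is 95000 nM, ranging from 40000 nM to 220000 nM.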

Compound 4, concentration for total growth inhibition: 1550 nM
Compound 4: the middle estimate sits 61-fold (1.79 log units) above what was measured; measured number below the stated range.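

In this assay, the benzyl on selenium is not needed for activity: going from benzyl to methyl gives a 41-fold lower number from compound 3 to compound 4 (1.61 log units; beyond the scatter). Putting methyl on selenium in place of methyl on sulfur gives an at least 64-fold lower number from compound 2 to compound 4 (1.80 log units; beyond the scatter), so the atom that carries the methyl matters greatly here. That second step is only a floor, as compound 2 stands at a limit: the limit of > 100000 nM in this assay, at which 2 of the 4 values shown sit.

An ethyl group or a longer chain on selenium could fall anywhere relative to methyl and benzyl. On these data alone, whether selenium has the same effect with the chlorine-bearing groups of compound 1 also stays open.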